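The compounds below may be only part of what the source reports. "The series", "measured", "known", "first", "only" and "open" are said of these compounds alone.

Measured so far:
Compound 1 `CCCCCCCCCc1cc2cn(COCCO)c(=O)nc2o1` in a functional assay on HEL cells (Homo sapiens) (a lower number here means that less compound is tolerated, a higher number that more compound is tolerated), gives >= 100000 nM, which is a limit of the assay.
Compound 2 `CO[C@H]1[C@H](O)[C@@H](O)[C@@H](O)O[C@@H]1C(=O)O` in this assay gives 130000 nM.
Compound 3 `CCCCCc1cc2cn(COCCO)c(O)nc-2n1` in this assay gives > 200000 nM, which is a limit of the assay.

Compound 1 thus stands at a limit rather than a number (the limit of >= 100000 nM in this assay, at which 1 of the 3 values shown sits). Compound 3 likewise stands at a limit (the limit of > 200000 nM in this assay, at which 1 of the 3 values shown sits). Among the measured compounds shown here, only compound 2 supplies a number, and no pair of measured compounds differs in a single place, so no measured step exists.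

Compound 4 `CCCCCCCCCCCc1cc2cn(COCCO)c(=O)nc2o1` differs from compound 1 by ethyl in place of hydrogen on a saturated chain carbon, nine bonds along the chain from an aromatic carbon. Lengthening the chain this way is expected to give no step beyond the usual scatter in this assay, an estimated step of a number no higher from compound 1 to compound 4 (the limit leaves the size open). Compound 4 is therefore expected near 100000 nM, with a range from 50000 nM to 200000 nM, and will most likely again be reported only as a limit.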

Compound 4, half-maximal cytotoxic concentration: 132000 nM
Beside the measured number, compound 4's estimate is 1.3-fold (0.12 log units) below it; low and high end bracket the measured number.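

Among the compounds shown here, no step from compound 1 to compound 4 can be read in this assay: the value of compound 1 is a limit of the assay, not a number. From the compounds shown here alone, how far this lengthening of the chain shifts the tolerated concentration, if at all, stays open.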